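The source may report more compounds than this note shows. Statements on the series, on what has been measured and on what is new or still open speak of the compounds shown alone.

Measured compounds:
- Compound 1, `CN1CCN(c2nccc3nc(-c4ccc(F)c(F)c4)[nH]c23)CC1`: 130000 nM
- Compound 2, `NC1CCN(c2nccc3[nH]c(-c4cccc(OC(F)(F)F)c4)nc23)CC1`: 200000 nM

Both numbers come from a physicochemical assay for solubility, read by HPLC, using the shake flask method, in phosphate buffer, with a stated time of 20 h, at pH 6.5 (on this read-out lower numbers stand for lower solubility and higher numbers for higher solubility), and the two lie within the scatter of each other, so neither compound can be called the more soluble one. Compound 2 simply has the higher of the two figures, with compound 1 close beside it.

Compound 3, `CN1CCN(CC2CCN(c3nccc4[nH]c(-c5cccc(OC(F)(F)F)c5)nc34)CC2)CC1`, has not yet been measured. It differs from compound 2 in one place: (4-methylpiperazin-1-yl)methyl in place of amino on a saturated ring carbon. Going by the values given here, no pair of measured compounds shows a step of this kind, so the size of the effect on this assay is not known from the numbers at hand. The nearest point of comparison is compound 1, which also carries a methylpiperazine ring and gives 130000 nM in this assay. On that basis, a step no larger than the scatter is expected, if anything toward a slightly lower number, a 1.7-fold lower number from compound 2 to compound 3 (0.22 log units; within the scatter). For compound 3 the estimate is 120000 nM, with a range from 40000 nM to 350000 nM.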

Compound 3, solubility: 200000 nM
Compound 3: the middle estimate sits 1.7-fold (0.22 log units) below what was measured, within the range that was stated.
By their numbers in this assay, from the lowest: compounds 1, 2 and 3 (each within the scatter of the next).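

In this assay, putting (4-methylpiperazin-1-yl)methyl in place of amino on the saturated ring carbon gives no change at the digits printed from compound 2 to compound 3 (within the scatter). Going by these compounds alone, this is the first direct reading at this position, and it shows that a single nitrogen can give way to a group of 8 heavy atoms with its own six-membered ring, and that losing the hydrogen-bond donor of the amino group leaves the figure the same within the scatter. No measurement in hand accounts for this result.

This single step cannot show whether the position would respond the same way to other groups, such as a carboxylic acid or a hydroxyl on the same ring carbon. It also leaves open whether a longer chain between that carbon and the methylpiperazine ring would give a similar number.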